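This account rests on a few compounds, and the source may have more. Where it says the series, first, only, none or still open, it means among the compounds named here.

In a functional assay on SMMC-7721 cells (Homo sapiens) for inhibition, read by CCK-8 assay, with a stated time of 72 h (a higher number here means a weaker inhibitor, a lower number a stronger inhibitor), compound 1 `O=C(NO)c1ccc(CNC(=O)c2n[nH]cc2NC(=O)c2c(Cl)cccc2Cl)cc1` gives 14600 nM and compound 2 `Nc1ccccc1NC(=O)c1ccc(CNC(=O)c2n[nH]cc2NC(=O)c2c(Cl)cccc2Cl)cc1` gives 7760 nM so the two stand level within the scatter. Compound 3 `Nc1ccccc1NC(=O)c1ccc(CNC(=O)c2n[nH]cc2NC(=O)c2c(F)cccc2F)cc1` differs from compound 2 in one place, with 2,6-difluorophenyl in place of 2,6-dichlorophenyl on a carbonyl carbon is the whole change. Among the compounds with values here, the only measured step, a 1.9-fold lower number from compound 1 to compound 2 (0.27 log units; within the scatter), concerns 2-aminophenyl in place of hydroxy and so does not test this change. No step beyond the scatter is therefore expected in this assay and the expected size is a 1.2-fold higher number from compound 2 to compound 3 (0.06 log units; within the scatter) as estimated. For compound 3 the estimated value is 9000 nM with an expected range of 3500 nM to 22000 nM as its bounds.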

Compound 3, half-maximal inhibitory concentration: 15200 nM
For compound 3 the middle estimate is 1.7-fold (0.23 log units) below the measured one, and the stated range covers the measured number.
By their numbers in this assay, from the lowest: compounds 2, 1 and 3 (each within the scatter of the next).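

On a carbonyl carbon whose other neighbour is an amide-type nitrogen, 2,6-difluorophenyl in place of 2,6-dichlorophenyl brings a 2.0-fold higher number from compound 2 to compound 3 (0.29 log units; within the scatter) in this assay and so does not separate the two compounds. This is the first change shown at this position, and it leaves the two compounds level. Nothing available explains this result. The compounds shown leave open whether an unsubstituted phenyl or a 2,6-dimethoxyphenyl on that carbonyl carbon would give a step beyond the scatter.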